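Swapping one side group on the shared core

The source may report more compounds than this note shows. Statements on the series, on what has been measured and on what is new or still open speak of the compounds shown alone.

- Compound 1 `CC#Cc1cncc(-c2ccc3c(c2)[C@@]2(COC(N)=N2)c2cc(-c4ccnc(F)c4)ncc2O3)c1`: 15 nm/s
- Compound 2 `NC1=N[C@@]2(CO1)c1cc(NC(=O)c3ccc(Cl)cn3)ccc1Oc1cnc(Cl)cc12`: 28 nm/s

In an ADME assay on LLC-PK1 cells (Sus scrofa) for permeability, read by LC-MS, with a stated time of 2 h, tested at 5 uM (on this read-out higher numbers stand for higher permeability and lower numbers for lower permeability), compound 2 gives 28 nm/s. This lies within the usual scatter of compound 1 at 15 nm/s, so the two values cannot be told apart.

Compound 3 `CC#Cc1cncc(-c2ccc3c(c2)[C@@]2(COC(N)=N2)c2cc(Cl)ncc2O3)c1` differs from compound 2 in one place: 5-(prop-1-yn-1-yl)pyridin-3-yl in place of ((5-chloropyridin-2-yl)carbonyl)amino on an aromatic carbon. Going by the values given here, no measured pair isolates this change, so any expectation rests on just these two values. Compound 1 also carries 5-(prop-1-yn-1-yl)pyridin-3-yl and gives 15 nm/s, which is within the scatter of compound 2, so no shift beyond the scatter is expected in this assay. The expected 1.1-fold lower number from compound 2 to compound 3 (0.05 log units; within the scatter) stays within the scatter. Compound 3 is estimated at 25 nm/s, with an expected range from 12 nm/s to 50 nm/s.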

Compound 3, apparent permeability: 22 nm/s
The estimate for compound 3 lay 1.1-fold (0.06 log units) above the measured number; low and high end bracket the measured number.
By their numbers in this assay, from the lowest: compounds 1, 3 and 2 (each within the scatter of the next).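

Both steps in this assay can now be read, and neither leaves the scatter. At the aromatic carbon of the all-carbon ring, a group with a hydrogen-bond donor gives way to one without, with a 1.3-fold lower number from compound 2 to compound 3 (0.10 log units; within the scatter), so this exchange of two quite different pyridine-bearing groups does not separate the compounds on this read-out. Chloro in place of 2-fluoropyridin-4-yl at the other varied aromatic carbon gives a 1.5-fold higher number from compound 1 to compound 3 (0.17 log units; within the scatter), and no information is available to explain either result.

On these data alone, whether any group at these places can move the number beyond the scatter remains open, since all three compounds lie within it. An amine, a carboxylic acid or a longer chain on the same aromatic carbon could test this, and the outcome cannot be told from these values.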